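A few compounds are considered here, and "the series" means these few. Any claim that something is new, unique, unknown or untested is made for them only; others in the source may bear on it.

Measured in a functional assay on MDA-MB-231 cells (Homo sapiens) for antiproliferative activity, read by CCK-8 assay, with a stated time of 48 h; a higher number here means a weaker inhibitor, a lower number a stronger inhibitor:
Compound 1 `COc1ccc2[nH]c(C)c(C3=C(Br)C(=O)C(c4c(-c5ccccc5)[nH]c5ccccc45)=C(Br)C3=O)c2c1` gives 5.02 ug/mL.
Compound 2 `COc1ccc2[nH]c(C)c(C3=C(Br)C(=O)C(c4c(-c5ccc(C)cc5)[nH]c5ccccc45)=C(Br)C3=O)c2c1` gives 3.99 ug/mL.
Compound 3 `Cc1[nH]c2ccccc2c1C1=C(Br)C(=O)C(Br)=C(c2c(-c3ccccc3)[nH]c3ccccc23)C1=O` gives 4.33 ug/mL.

Compound 1 and compound 2 share a core and differ only at the phenyl group, where the change is methyl in place of hydrogen on an aromatic carbon. This change made a step of a 1.3-fold lower number from compound 1 to compound 2 (0.10 log units; within the scatter), so the two numbers lie within the usual scatter of each other.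

Compound 3 carries a different core, and the difference between the two cores is not broken down here. Its value sits close to those of compound 1 and compound 2, and none of the three can be set apart from the others.

Compound 4 `Cc1ccc(-c2[nH]c3ccccc3c2C2=C(Br)C(=O)C(Br)=C(c3c(C)[nH]c4ccccc34)C2=O)cc1` is not yet measured. It stands to compound 3 as compound 2 stands to compound 1: the change is methyl in place of hydrogen on an aromatic carbon, the same change at the same kind of place. Because the earlier step was a 1.3-fold lower number from compound 1 to compound 2 (0.10 log units; within the scatter), the step to compound 4 is expected to be small, a 1.2-fold lower number from compound 3 to compound 4 (0.09 log units; within the scatter). Compound 4 is expected to give about 3.5 ug/mL in this assay, most likely between 1.8 ug/mL and 7 ug/mL.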

Compound 4, half-maximal inhibitory concentration: 5.89 ug/mL
Compound 4: the middle estimate sits 1.7-fold (0.23 log units) below what was measured; low and high end bracket the measured number.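

In this assay, putting methyl in place of hydrogen on the phenyl group of compound 3 gave a 1.4-fold higher number from compound 3 to compound 4 (0.13 log units; within the scatter). This step lies within the scatter. Set beside the earlier step, it shows that this change left the number within the scatter on both cores, and that the two cores cannot be told apart in their response to it: the same change on two cores in this assay, a 1.3-fold lower number (0.10 log units; within the scatter) from compound 1 to compound 2 and a 1.4-fold higher number (0.13 log units; within the scatter) from compound 3 to compound 4, 1.7-fold (0.23 log units) apart, within the scatter of two such steps. It does not show that the change carries a real effect from one core to the other, since neither step can be given a direction, and so agreement between the cores has been seen only for a change that does little on either.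

The compounds shown leave open whether a larger or different group at the same place, such as a methoxy group, an amine, a carboxylic acid or a longer chain, would move the number beyond the scatter. They also leave open whether any such step would then be the same on both cores.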